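The compounds below may be only part of what the source reports. "The series", "measured", "known", "first", "only" and "open" are said of these compounds alone.

Of the compounds shown here, three have so far been tested in a functional assay on SW1573 cells (Homo sapiens) for antiproliferative activity; on this read-out lower numbers stand for stronger inhibition of growth and higher numbers for weaker inhibition of growth. Compound 1, `CC(C)CC1C=C(Cl)CCO1`, reaches only the edge of the assay: in this assay compound 1 gives > 100000 nM, which is a limit rather than a number. Compound 2, `C[C@H]1CC(Cl)=C([Si](C)(C)C)[C@@H](C2CCCCC2)O1`, in this assay gives 16000 nM. Compound 3, `ClC1=CC(CCC=C(Br)Br)OCC1`, in this assay gives 30000 nM. Of the two actual numbers, compound 3 holds the higher one, but its gap to compound 2 lies within the scatter of repeated measurements, so the two cannot be separated on this read-out; the remaining value is a limit and not a number.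

Compound 4, `C#CCCC1C=C(Cl)CCO1`, is still to be measured. It differs from compound 3 in a single place: ethynyl in place of 2,2-dibromoethenyl on a saturated chain carbon, two bonds along the chain from a saturated ring carbon. Within the data shown here, no step between measured compounds has been recorded, so there is no direct guide to what this exchange does. Among the measured compounds shown here, the only loose pointer is compound 1, whose side chain also carries no bromine: in this assay compound 1 gives > 100000 nM, a limit. On that slender basis a weakening of growth inhibition is expected, a step of about a 2.0-fold higher number from compound 3 to compound 4 (0.30 log units; within the scatter) in this assay. Compound 4 is estimated at 60000 nM, with a likely range from 20000 nM to 150000 nM.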

Compound 4, concentration for 50% growth inhibition: 41000 nM
Compound 4: middle estimate off by 1.5-fold (0.17 log units), on the high side; the range from low to high includes it.
By their numbers in this assay, from the lowest: compounds 2, 3 and 4 (each within the scatter of the next, the first and the last beyond it). At a limit, above all of these: compound 1.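

In this assay, among these compounds, the first exchange at this position gives a 1.4-fold higher number from compound 3 to compound 4 (0.14 log units; within the scatter), with ethynyl in place of 2,2-dibromoethenyl on a saturated chain carbon, two bonds along the chain from a saturated ring carbon. The two compounds cannot be told apart on this read-out, so a side chain without bromine and with two fewer heavy atoms can keep the same level of growth inhibition, and the absence of bromine in compound 1 is no sign of a loss here. The group at this place still counts, as a second comparison gives an at least 2.4-fold lower number from compound 1 to compound 4 (0.38 log units; beyond the scatter), with propargyl in place of isopropyl on a saturated chain carbon bound to a saturated ring carbon, and that step can only be read as a minimum, for compound 1 stands at a limit and not at a number: the limit of > 100000 nM in this assay, at which 1 of the 4 values shown sits.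

As far as these compounds go, what an amine, a carboxylic acid or a longer chain would do in place of ethynyl remains open. So does the effect of fluorine in place of the chlorine on the shared core, for all four compounds shown carry chlorine.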